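This account rests on a few compounds, and the source may have more. Where it says the series, first, only, none or still open, it means among the compounds named here.

Measured so far in a functional assay on the whole organism (blood) with Rattus norvegicus as the target, with stated times of 24 h and 1 h, at a dose of 1 mg/kg by the intraperitoneal route; on this read-out lower numbers stand for a weaker effect and higher numbers for a stronger effect at the one dose given:

Compound 1, `COc1ncccc1C(=O)NCCC1CCN(S(=O)(=O)NC(=O)NC2CCCCC2)CC1`: 22%
Compound 2, `O=C(NC1CCCCC1)NS(=O)(=O)N1CCC(CCNC(=O)c2cccc3cccnc23)CC1`: 29%

Among the measured compounds shown here, compound 2 sits at 29% in this assay, and the only other number, that of compound 1, lies within the scatter of it: a number 7 percentage points higher from compound 1 to compound 2 (within the scatter). Compound 3, `O=C(NC1CCCCC1)NS(=O)(=O)N1CCC(CCNC(=O)c2cc(Cl)cc3cccnc23)CC1`, carries chloro in place of hydrogen on an aromatic carbon. For the measured compounds named here, no measured step touches this position or this group; the single step on record changed a different part of compound 2 and stayed within the scatter. No pull in either direction is therefore expected, and compound 3 is estimated at a number 1 percentage points higher from compound 2 to compound 3 (within the scatter). For compound 3 the expected reading in this assay is 30%, with a range from 15% to 45%.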

Compound 3, a percentage reported as activity, at one dose (the size of the read-out at that dose, not a potency): 17%
Compound 3: the middle estimate sits 13 percentage points above what was measured; low and high end bracket the measured number.
By their numbers in this assay, from the lowest: compounds 3, 1 and 2 (each within the scatter of the next, the first and the last beyond it).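

Chloro on this aromatic carbon of the quinolin-8-yl group gives the only step shown that lies beyond the scatter, a number 12 percentage points lower from compound 2 to compound 3 (beyond the scatter), in this assay. Set against the group on the carbonyl carbon of compound 1, however, the 6-chloroquinolin-8-yl group gives a number 5 percentage points lower from compound 1 to compound 3 (within the scatter), so those two groups cannot be told apart on this read-out. Nothing available explains the effect of the chloro group. The compounds shown leave open whether fluoro, methoxy or an amine on the same carbon would read as chloro does. They also leave open whether chloro would give the same step on other carbons of that ring.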